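This account rests on a few compounds, and the source may have more. Where it says the series, first, only, none or still open, it means among the compounds named here.

Three compounds have been measured in a functional assay on HeLa cells (Homo sapiens) for cytotoxicity, read by MTT assay, with a stated time of 48 h, tested at 50 uM; a higher number here means a stronger effect of the compound at the concentration tested, a lower number a weaker effect:

compound 1, `CS(=O)(=O)c1ccc(Cc2n[nH]c(=S)n2/N=C/c2c(F)cccc2Cl)cc1`, gives 70.6%
compound 2, `CS(=O)(=O)c1ccc(Cc2n[nH]c(=S)n2/N=C/c2ccc(F)cc2)cc1`, gives 26.3%
compound 3, `CS(=O)(=O)c1ccc(Cc2n[nH]c(=S)n2/N=C/c2ccccc2Cl)cc1`, gives 42.7%

Compound 3 stands second highest of these three numbers. Its nearest neighbour is compound 2, separated by a number 16.4 percentage points higher from compound 2 to compound 3 (beyond the scatter), and its furthest is compound 1, separated by a number 27.9 percentage points lower from compound 1 to compound 3 (beyond the scatter). Both steps are beyond the scatter.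

Compound 4, `CS(=O)(=O)c1ccc(Cc2n[nH]c(=S)n2/N=C/c2cccs2)cc1`, is the next compound, not yet measured. It differs from compound 3 in one place: thiophen-2-yl in place of 2-chlorophenyl on a carbon with a double bond to nitrogen. Among the measured compounds shown here, no measured step swaps the ring itself on that carbon; the two steps that come closest change only what sits on a six-membered ring there. Compound 2, which carries no chlorine and no second substituent next to the ring carbon that bears the double-bonded carbon, sits lowest, so taking the 2-chlorophenyl away is read as a likely loss of effect in this assay, of modest size. Compound 4 is therefore estimated to give about 30%, within a range from 12% to 50%. This estimate means an expected change of a number 12.7 percentage points lower from compound 3 to compound 4 (beyond the scatter).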

Compound 4, a percentage reported as activity, at one concentration (the size of the read-out at that concentration, not a potency): 48.6%
Beside the measured number, compound 4's estimate is 18.6 percentage points below it, within the range that was stated.
By their numbers in this assay, from the lowest: compound 2; then compounds 3 and 4 (each within the scatter of the next); then compound 1.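

In this assay, replacing the six-membered ring on the carbon with a double bond to nitrogen by a five-membered thiophen-2-yl ring gives a number 5.9 percentage points higher from compound 3 to compound 4 (within the scatter) and so leaves no readable difference, which shows that this position accepts more than substituted phenyl rings. Compound 4 carries no chlorine, yet the step from the chlorine-free 4-fluorophenyl ring gives a number 22.3 percentage points higher from compound 2 to compound 4 (beyond the scatter), so lacking chlorine does not by itself bring a low number here, while the step from the 2-chloro-6-fluorophenyl ring gives a number 22 percentage points lower from compound 1 to compound 4 (beyond the scatter) and that ring keeps its lead. No measurement of any other kind is available to explain these differences.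

From the compounds shown here alone, it remains open what an unsubstituted phenyl ring would give at this place, which would separate the effect of the ring from that of its substituents. A furan-2-yl or pyridin-2-yl ring would show whether the thiophen-2-yl result extends to other rings containing a hetero atom.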